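A few compounds are considered here, and "the series" means these few. Any claim that something is new, unique, unknown or untested is made for them only; others in the source may bear on it.

Of the compounds shown here, two have been measured in an assay on isolated protein with Bile acid receptor (Homo sapiens) as the target; on this read-out higher numbers stand for an effect only at larger amounts of compound and lower numbers for an effect already at smaller amounts. Compound 1 `COC(=O)/C=C/c1cccc(N(Cc2ccc(/C=C/c3cccc(F)c3)cc2)C(=O)C2CCCCC2)c1` gives 86 nM, and compound 2 `COC(=O)/C=C/c1cccc(N(Cc2ccc(-c3ccc(F)c(Cl)c3)cc2)C(=O)C2CCCCC2)c1` gives 66 nM, the lowest of the two numbers, though the difference is only a 1.3-fold lower number from compound 1 to compound 2 (0.11 log units; within the scatter). Compound 3 `COC(=O)/C=C/c1cccc(N(Cc2ccc(-c3c(OC)cccc3OC)cc2)C(=O)C2CCCCC2)c1` differs from compound 2 by 2,6-dimethoxyphenyl in place of 3-chloro-4-fluorophenyl on an aromatic carbon. For the measured compounds named here, the single measured step also exchanged the group at this same place and stayed within the scatter, so a further exchange there is expected to move this assay only modestly, if at all. Compound 3 is therefore expected at 130 nM, with a range from 45 nM to 400 nM. The expected step is a 2.0-fold higher number from compound 2 to compound 3 (0.29 log units; within the scatter).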

Compound 3, half-maximal effective concentration: 77 nM
Estimate against measurement, compound 3: 1.7-fold (0.23 log units) above, and the stated range covers the measured number.
By their numbers in this assay, from the lowest: compounds 2, 3 and 1 (each within the scatter of the next).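

In this assay, the step to 2,6-dimethoxyphenyl, which carries hydrogen-bond acceptors where 3-chloro-4-fluorophenyl has none, is a 1.2-fold higher number from compound 2 to compound 3 (0.07 log units; within the scatter), and the step from the 2-(3-fluorophenyl)ethenyl group is a 1.1-fold lower number from compound 1 to compound 3 (0.05 log units; within the scatter). This place on the aromatic ring has now held three different groups, halogen-bearing and methoxy-bearing, without any step beyond the scatter. No evidence here explains this flat result. Still open, on these data alone, is whether an amine or a carboxylic acid at this place would move the number, and whether the ring can be replaced by a single methyl.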